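This account rests on a few compounds, and the source may have more. Where it says the series, first, only, none or still open, it means among the compounds named here.

Of the compounds shown here, two built on one shared core have so far been measured in a functional assay on Ehrlich cells (Mus musculus) for cytotoxicity, read by trypan blue exclusion, with a stated time of 2 h, tested at 10 ug/mL; on this read-out higher numbers stand for a stronger effect at the one concentration tested and lower numbers for a weaker effect. Compound 1 `N#CC1=C(N)N(c2ccc(S(N)(=O)=O)cc2)C2=C(CCCC2)C1c1ccc(O)cc1` gives 20% in this assay, and compound 2 `COc1ccc(C2C(C#N)=C(N)N(c3ccc(S(N)(=O)=O)cc3)C3=C2CCCC3)cc1` gives 50%. For the measured compounds named here, the one measured step, a number 30 percentage points higher from compound 1 to compound 2 (beyond the scatter), is the only comparison available. Going by the values given here, on these two numbers compound 2 stands highest; compound 1 is the only other number, and it lies lower by a step beyond the scatter.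

Compound 3 `N#CC1=C(N)N(c2ccc(S(N)(=O)=O)cc2)C2=C(CCCC2)C1c1ccc(Cl)cc1Cl` has not yet been measured. It differs from compound 2 in the group on a saturated ring carbon of the core: 2,4-dichlorophenyl in place of 4-methoxyphenyl on a saturated ring carbon. Among the compounds with values here, the measured step concerned only methyl in place of hydrogen on an oxygen of the 4-methoxyphenyl group, whereas here the whole 4-methoxyphenyl group leaves and 2,4-dichlorophenyl enters, so no measured step bears directly on this change, and no direction can be read from the data. The expectation is therefore a step of a number 5 percentage points lower from compound 2 to compound 3 (within the scatter), which is within the scatter and carries wide uncertainty. Compound 3 is estimated to give 45% in this assay, within a range from 15% to 75%.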

Compound 3, a percentage reported as activity, at one concentration (the size of the read-out at that concentration, not a potency): 0%
Compound 3: the middle estimate sits 45 percentage points above what was measured, outside the stated range (below it).
By their numbers in this assay, from the lowest: compound 3; then compound 1; then compound 2.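

The earlier step changed only a methyl on the oxygen of the aryl group, while this change replaces the whole group on the saturated ring carbon, and it shows that the read-out depends strongly on what sits there: in this assay the swap from 4-methoxyphenyl to 2,4-dichlorophenyl gives a number 50 percentage points lower from compound 2 to compound 3 (beyond the scatter) and leaves compound 3 at 0% in this test at one concentration. The same group also falls short of the 4-hydroxyphenyl group, with a number 20 percentage points lower from compound 1 to compound 3 (beyond the scatter) even though that compound was already the weaker of the first two, so among these three compounds both aryl groups bearing oxygen give higher numbers than the one bearing chlorine. Nothing measured here explains why the 2,4-dichlorophenyl group gives this result.

This single swap removes the oxygen and adds two chlorines at once, so the compounds shown cannot tell which of these changes matters, or whether both do. Also open, from the compounds shown here alone, is how a plain phenyl group, or a phenyl group carrying an amine or a carboxylic acid, would read at this saturated ring carbon.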